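A few compounds are considered here, and "the series" means these few. Any claim that something is new, unique, unknown or untested is made for them only; others in the source may bear on it.

Compound 1 `CCCCCCCCCCCCCCNC(=O)[C@@H](NC(=O)c1ccco1)[C@@H](C)O` in a functional assay on HepG2 cells (Homo sapiens) for cytotoxicity, read by MTT assay, with a stated time of 48 h (a higher number here means a weaker inhibitor, a lower number a stronger inhibitor), gives > 400000 nM, which is a limit of the assay rather than a number.
Compound 2 `CCCCCCCCCCCCCCNC(=O)[C@@H](NC(=O)c1cc2ccccc2[nH]1)[C@@H](C)O` gives 10500 nM.
Compound 3 `CCCCCCCCCCCCCCNC(=O)[C@@H](NC(=O)/C=C/c1ccccc1)[C@@H](C)O` gives 150000 nM.

Among the numbers shown, compound 3 has the highest, with compound 2 the nearest, a 14-fold higher number from compound 2 to compound 3 (1.15 log units; beyond the scatter); the value of compound 1 is a limit only (the limit of > 400000 nM in this assay, at which 1 of the 3 values shown sits). Compound 4 `CCCCCCCCCCCCCCNC(=O)[C@@H](NS(=O)(=O)c1cccs1)[C@@H](C)O` differs from compound 3 in one place: (thiophen-2-yl)sulfonyl in place of (2-phenylethenyl)carbonyl on an amine nitrogen. Going by the values given here, no measured step swaps a carbonyl for a sulfonyl, so the steps that bear on it are those exchanging the group on the carbonyl: an at least 38-fold lower number from compound 1 to compound 2 (1.58 log units; beyond the scatter), an at least 2.6-fold lower number from compound 1 to compound 3 (0.42 log units; beyond the scatter) and a 14-fold higher number from compound 2 to compound 3 (1.15 log units; beyond the scatter). The furan-2-yl of compound 1 sits at the limit, the 1H-indol-2-yl of compound 2 gives the lowest number, and the 2-phenylethenyl of compound 3 lies between. The thiophen-2-yl entering in compound 4 is, like the furan-2-yl of compound 1, a five-membered aromatic ring with 1 hetero atom, so a return toward the limit of compound 1 is expected. Compound 4 is therefore expected to show a 2.0-fold higher number from compound 3 to compound 4 (0.30 log units; within the scatter). Compound 4 is estimated at 300000 nM, between 80000 nM and 1500000 nM, with a fair chance that only a limit is reported.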

Compound 4, half-maximal inhibitory concentration: 21600 nM
For compound 4 the middle estimate is 14-fold (1.14 log units) above the measured one; the measured number lies below the stated range.
By their numbers in this assay, from the lowest: compound 2; then compound 4; then compound 3. At a limit, above all of these: compound 1.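

Placing (thiophen-2-yl)sulfonyl on the amine nitrogen does not send the number back toward the weak end of the set, although the five-membered ring of compound 1 shares its ring type (a 6.9-fold lower number from compound 3 to compound 4 (0.84 log units; beyond the scatter)). The new group comes close to the (1H-indol-2-yl)carbonyl group, yet compound 2 keeps the lower number (a 2.1-fold higher number from compound 2 to compound 4 (0.31 log units; beyond the scatter)), while the gap to the (furan-2-yl)carbonyl group is large (an at least 18-fold lower number from compound 1 to compound 4 (1.26 log units; beyond the scatter)). The value of compound 1 is a limit of the assay and not a number, so this last step is a bound only: the limit of > 400000 nM in this assay, at which 1 of the 4 values shown sits.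

The compounds shown leave open how much of the change belongs to the sulfonyl and how much to the thiophen-2-yl, which a (thiophen-2-yl)carbonyl group on the same nitrogen would separate. Going by these compounds, whether a phenylsulfonyl or a (1H-indol-2-yl)sulfonyl group would lower the number further also stays open.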